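Swapping a dimethylamino-phenyl for a pyrimidine ring

This account rests on a few compounds, and the source may have more. Where it says the series, first, only, none or still open, it means among the compounds named here.

Compounds measured in an assay on LM cells for displacement of a labelled ligand from Neuropeptide Y receptor type 5 (Homo sapiens); a lower number here means a stronger inhibitor, a higher number a weaker inhibitor:
- compound 1 `Fc1ccc(C2(c3ccc(F)cc3)CNC(c3ccccc3)=N2)cc1` gives 32 nM
- compound 2 `Fc1ccc(C2(c3ccc(F)cc3)CNC(c3cccc(F)c3)=N2)cc1` gives 10 nM
- compound 3 `CN(C)c1cccc(C2=NC(c3ccc(F)cc3)(c3ccc(F)cc3)CN2)c1` gives > 1000 nM

The value of compound 3 is a limit of this assay, not a number (the limit of > 1000 nM in this assay, at which 1 of the 3 values shown sits). Compound 3 therefore stands at the weak end of the three compounds shown. The two measured steps that lead to it are large: an at least 31-fold higher number from compound 1 to compound 3 (1.49 log units; beyond the scatter) and an at least 100-fold higher number from compound 2 to compound 3 (2.00 log units; beyond the scatter). Both say that placing a dimethylamino group on the aromatic ring attached to the shared core costs a great deal of potency, whereas the fluoro-for-hydrogen exchange a 3.2-fold lower number from compound 1 to compound 2 (0.51 log units; beyond the scatter) is only modest.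

Compound 4 `Fc1ccc(C2(c3ccc(F)cc3)CNC(c3cncnc3)=N2)cc1` goes a different way: pyrimidin-5-yl in place of 3-(dimethylamino)phenyl on a carbon with a double bond to nitrogen. Among the compounds with values here, the dimethylamino group that accompanied the collapse in compound 3 is gone, so a return toward the numbers of compounds 1 and 2 is expected, though no measured compound carries a pyrimidine, so the size of that return is uncertain. The expected step is an at least 6.6-fold lower number from compound 3 to compound 4 (0.82 log units; beyond the scatter). For compound 4 the estimate is 150 nM, with a likely range from 30 nM to 800 nM in this assay.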

Compound 4, half-maximal inhibitory concentration: 47 nM
Beside the measured number, compound 4's estimate is 3.2-fold (0.50 log units) above it; the range from low to high includes it.
By their numbers in this assay, from the lowest: compound 2; then compounds 1 and 4 (each within the scatter of the next). At a limit, above all of these: compound 3.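

In this assay, this position on the carbon with a double bond to nitrogen accepts a ring that carries two nitrogen atoms, and the potency lost in compound 3 comes back with pyrimidin-5-yl: an at least 21-fold lower number from compound 3 to compound 4 (1.32 log units; beyond the scatter). Against the plain phenyl ring, the pyrimidin-5-yl group makes no difference that can be told apart (a 1.5-fold higher number from compound 1 to compound 4 (0.17 log units; within the scatter)), so placing ring nitrogen atoms here does not by itself cost potency, although this group falls short of the 3-fluorophenyl group (a 4.7-fold higher number from compound 2 to compound 4 (0.67 log units; beyond the scatter)). The first of these steps gives only a lower bound, since the value of compound 3 is a limit of the assay and not a number: the limit of > 1000 nM in this assay, at which 1 of the 4 values shown sits.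

The compounds shown leave open whether a pyridine ring would match the pyrimidine ring or the fluorinated phenyl ring. They also do not tell whether a smaller amine on the phenyl ring, such as methylamino or a free amino group, would bring the same collapse as dimethylamino, or whether a fluoro group on the pyrimidine ring would add potency as it does on the phenyl ring.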